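The source may report more compounds than this note shows. Statements on the series, on what has been measured and on what is new or still open speak of the compounds shown alone.

Measured so far in a functional assay on NCI-H460 cells (Homo sapiens) for cytotoxicity, read by MTT assay, with a stated time of 72 h; a lower number here means a stronger inhibitor, a higher number a weaker inhibitor:
compound 1 `COc1cc2c(Oc3ccc(NC(=O)c4cn(-c5ccccc5C)nn4)cc3F)ccnc2cc1OCCCN1CCCCC1` gives 2100 nM
compound 2 `COc1cc2c(Oc3ccc(NC(=O)c4cn(-c5ccccc5F)nn4)cc3F)ccnc2cc1OCCCN1CCCCC1` gives 210 nM
compound 3 `COc1cc2c(Oc3ccc(NC(=O)c4cn(-c5ccccc5F)nn4)cc3F)ccnc2cc1OCCCN1CCC(C)CC1` gives 190 nM

Compound 4 `COc1cc2c(Oc3ccc(NC(=O)c4cn(-c5ccccc5C)nn4)cc3F)ccnc2cc1OCCCN1CCC(C)CC1` awaits measurement. Its core differs from that of compound 2 by methyl in place of hydrogen on a saturated ring carbon, a change that gave a 1.1-fold lower number from compound 2 to compound 3 (0.04 log units; within the scatter). The change from compound 3 to compound 4 is methyl in place of fluoro on an aromatic carbon. The same change occurs once before, from compound 2 to compound 1, as methyl in place of fluoro on an aromatic carbon, where it gave a 10-fold higher number from compound 2 to compound 1 (1.00 log units; beyond the scatter). The surroundings of the place read the same in both cases, so this is the same change on a different core. With a single earlier instance, the expectation rests on that one step and on compound 3 at 190 nM. For compound 4 a step of a 10-fold higher number from compound 3 to compound 4 (1.00 log units; beyond the scatter) is expected in this assay. Compound 4 is accordingly estimated at 1900 nM, between 800 nM and 4500 nM.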

Compound 4, half-maximal inhibitory concentration: 2730 nM
Compound 4: middle estimate off by 1.4-fold (0.16 log units), on the low side; low and high end bracket the measured number.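

In this assay, methyl in place of fluoro on the aromatic carbon carries over between the two cores, with a 14-fold higher number from compound 3 to compound 4 (1.16 log units; beyond the scatter) closely matching the earlier step: the same change on two cores in this assay, a 10-fold higher number (1.00 log units; beyond the scatter) from compound 2 to compound 1 and a 14-fold higher number (1.16 log units; beyond the scatter) from compound 3 to compound 4, 1.4-fold (0.16 log units) apart, within the scatter of two such steps

Methyl in place of hydrogen on a saturated ring carbon also carries over, with a 1.3-fold higher number from compound 1 to compound 4 (0.11 log units; within the scatter) and no step beyond the scatter on either core: the same change on two cores in this assay, a 1.1-fold lower number (0.04 log units; within the scatter) from compound 2 to compound 3 and a 1.3-fold higher number (0.11 log units; within the scatter) from compound 1 to compound 4, 1.4-fold (0.16 log units) apart, within the scatter of two such steps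

Among the compounds shown here, this covers only two changes, each on two closely related cores in one cell assay, and it does not show why the steps have these sizes or that they would hold on a more distant core.

Still open, going by these compounds, is what a chloro or methoxy group would give in place of the fluoro of the 2-fluorophenyl group. Also open, on these data alone, is how a morpholine would compare with the saturated amine ring at the end of the chain.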